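The compounds below may be only part of what the source reports. "The series", "measured", "known", "first", "only" and "open" are said of these compounds alone.

Measured in an ADME assay on MRC5 cells (Homo sapiens) for antiproliferative activity, read by fluorescence and resazurin assay, with a stated time of 68 h; a lower number here means that less compound is needed, a higher number that more compound is needed for the effect:
- Compound 1 `Cc1cc(Nc2cc(C(=O)NCCN3CCCC3)c3cc(F)ccc3n2)on1`: > 50000 nM (a limit of the assay, not a number)
- Compound 2 `O=C(NCCN1CCCC1)c1cc(NCCN2CCCCC2)nc2ccc(F)cc12`: 19000 nM

Going by the values given here, compound 2 stands alone as the only true number in this assay, at 19000 nM. The other reading, for compound 1, is a limit. Compound 3 `O=C(NCCN1CCCC1)c1cc(NCCC2CCOCC2)nc2ccc(F)cc12` differs from compound 2 as follows: oxan-4-yl in place of piperidin-1-yl on a saturated chain carbon, two bonds along the chain from a nitrogen on an aromatic ring. This places oxan-4-yl in place of piperidin-1-yl on a saturated chain carbon, two bonds along the chain from a nitrogen on an aromatic ring.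

Among the compounds with values here, only one measured step bears on this change, and only indirectly: an at least 2.6-fold lower number from compound 1 to compound 2 (0.42 log units; beyond the scatter). Going by these compounds, that step brought in 2-(piperidin-1-yl)ethyl in place of 3-methyl-1,2-oxazol-5-yl on the same nitrogen, and its true size is unknown. Compound 3 keeps the chain and exchanges only the ring, so part of that gain may be lost, and a small move toward a higher number is expected, not clearly beyond the scatter. The expected change is a 1.6-fold higher number from compound 2 to compound 3 (0.20 log units; within the scatter). For compound 3 the estimate is 30000 nM, with an expected range of 12000 nM to 50000 nM.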

Compound 3, half-maximal effective concentration: > 50000 nM
Compound 3: a limit, no number; the forecaster's own chance of this, stated with the estimate: 25%; at least 1.6-fold (0.22 log units) between middle value and limit.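

In this assay, exchanging the piperidin-1-yl ring for an oxan-4-yl ring on the saturated chain carbon, two bonds along the chain from a nitrogen on an aromatic ring, gives an at least 2.6-fold higher number from compound 2 to compound 3 (0.42 log units; beyond the scatter), so the 2-(piperidin-1-yl)ethyl chain cannot be replaced by 2-(oxan-4-yl)ethyl without a clear loss, even though both rings have the same heavy-atom count and differ by one nitrogen against one oxygen. The reading of compound 3, > 50000 nM, is a limit of the assay and not a number. The step from compound 1 to compound 3 cannot be read, and the true number in this series still rests on compound 2 alone, with the other two compounds sitting at the same ceiling: the limit of > 50000 nM in this assay, at which 2 of the 3 values shown sit.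

Going by these compounds, whether the ring nitrogen of the piperidin-1-yl group is what matters stays open, and a morpholin-4-yl ring, an open-chain dimethylamino group or a longer chain carrying the piperidin-1-yl ring at this place would test that. With a single true number, the size of either step and any ranking among the rings remain unsettled.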